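The source may hold more compounds than are shown below. What is called first, only, known or untested is meant among the compounds shown, and "the series" means these compounds.

In a functional assay on MIA PaCa-2 cells (Homo sapiens) for inhibition, read by MTT assay, with a stated time of 4 days (on this read-out higher numbers stand for weaker inhibition and lower numbers for stronger inhibition), compound 1 `CCOC(=O)NC(c1ccccc1)c1ccc(Cl)cc1` gives 142000 nM and compound 2 `CCOC(=O)N(C)C(c1ccccc1)c1ccccc1` gives 94000 nM. Within the data shown here, these two values lie within the usual scatter of each other, so compound 1 stands at the same level as the only other measured compound. Among the measured compounds shown here, the two differ in more than one place, so no measured step is available to size a single change.

Compound 3 `NNC(=O)NC(c1ccccc1)c1ccc(Cl)cc1` carries aminoamino in place of ethoxy on a carbonyl carbon. For the measured compounds named here, with no measured precedent for this exchange, the expectation stays anchored on compound 1 at 142000 nM, and no shift beyond the scatter is anticipated in this assay. The expected change is a 1.4-fold lower number from compound 1 to compound 3 (0.15 log units; within the scatter), and its direction is uncertain. The estimated value for compound 3 is 100000 nM, with an expected range of 30000 nM to 250000 nM.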

Compound 3, half-maximal inhibitory concentration: 178000 nM
Beside the measured number, compound 3's estimate is 1.8-fold (0.25 log units) below it; the measured number falls inside the stated range.
By their numbers in this assay, from the lowest: compounds 2, 1 and 3 (each within the scatter of the next).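

Among these compounds, on the carbonyl carbon whose other neighbour is the amide-type nitrogen, the first single-place step in this assay puts aminoamino in place of ethoxy and reads a 1.3-fold higher number from compound 1 to compound 3 (0.10 log units; within the scatter). Although ethoxy carries 0 hydrogen-bond donors and aminoamino carries 2, this exchange gives no change that can be told from the scatter, so this one step shows that the position accepts aminoamino in the core of compound 1. Nothing measured on these compounds accounts for this result.

Going by these compounds, whether a longer chain such as butoxy, or a carboxylic acid in place of the ethoxycarbonyl group, would move the number beyond the scatter remains open. On these data alone, it also remains open whether the same exchange would behave alike in the core of compound 2.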